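A few compounds are considered here, and "the series" means these few. Any claim that something is new, unique, unknown or untested is made for them only; others in the source may bear on it.

In a functional assay on SK-MEL-28 cells (Homo sapiens) for inhibition, read by MTT assay, with a stated time of 72 h (on this read-out higher numbers stand for weaker inhibition of growth and lower numbers for stronger inhibition of growth), the methyl ester compound 1 (`COC(=O)/C=C/C1=CC[C@H]2C(C)(C)CCC[C@]2(C)[C@H]1C=O`) gives 27000 nM and the tert-butyl ester compound 2 (`CC(C)(C)OC(=O)/C=C/C1=CC[C@H]2C(C)(C)CCC[C@]2(C)[C@H]1C=O`) gives 41000 nM on the same core. Among the compounds with values here, these two values are the whole measured series so far, and the one step between them is a 1.5-fold higher number from compound 1 to compound 2 (0.18 log units; within the scatter) on this read-out. Compound 2 therefore stands level with compound 1 within the scatter.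

The next case is compound 3 (`COC(=O)/C=C/C=C/C1=CC[C@H]2C(C)(C)CCC[C@]2(C)[C@H]1C=O`), with this change: 2-(methoxycarbonyl)ethenyl in place of tert-butoxycarbonyl on a double-bonded chain carbon bound to a double-bonded chain carbon.

The ester step is the only measured one that bears on this change, and it covers only the swap of tert-butyl for methyl. Within the data shown here, no measured compound carries the 2-(methoxycarbonyl)ethenyl group, so the data leave that part open. The expectation rests on compound 2 at 41000 nM and on the ester step alone, so no shift beyond the scatter is expected in this assay and no direction is favoured.

The estimated move is a 1.6-fold lower number from compound 2 to compound 3 (0.21 log units; within the scatter) with wide uncertainty. Compound 3 is expected at 25000 nM as an estimate, within an estimated range of 9000 nM to 60000 nM for this read-out.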

Compound 3, concentration for 50% growth inhibition: 25000 nM
For compound 3 middle estimate and measured number coincide at the digits printed; the measured number falls inside the stated range.
By their numbers in this assay, from the lowest: compounds 3, 1 and 2 (each within the scatter of the next).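

In this assay, placing 2-(methoxycarbonyl)ethenyl on a double-bonded chain carbon bound to a double-bonded chain carbon, where tert-butoxycarbonyl stood, gives a 1.6-fold lower number from compound 2 to compound 3 (0.21 log units; within the scatter). The comparison with the methoxycarbonyl group at the same place gives a 1.1-fold lower number from compound 1 to compound 3 (0.03 log units; within the scatter), so this place now has a read on a change in the chain itself and not only on the alkyl part of the ester, and that change also stays level with the other two compounds. No measurement on hand accounts for this flat picture across the three esters.

The compounds shown all keep an ester at the end of the chain, so it remains open whether a carboxylic acid, a primary amide or an amine in that role would move the number beyond the scatter, and whether a longer chain of the same kind would do so. The aldehyde on the shared core is the same in all three compounds, which leaves its contribution unread until a primary alcohol or a carboxylic acid stands in its place.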